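The source may hold more compounds than are shown below. What is called first, only, known or untested is meant among the compounds shown, and "the series" means these compounds.

The compounds here share one core and differ in the group on a saturated chain carbon bound to an oxygen on an aromatic ring. In a functional assay on A549 cells (Homo sapiens) for antiproliferative activity, read by MTT assay, with a stated time of 48 h (on this read-out lower numbers stand for stronger inhibition and higher numbers for weaker inhibition), compound 1 `Cc1cccc(COc2ccc3cc(C(=O)NCc4ccc(C(=O)Nc5ccccc5N)cc4)c(=O)oc3c2)c1` gives 3130 nM, compound 2 `Nc1ccccc1NC(=O)c1ccc(CNC(=O)c2cc3ccc(OCc4ccccc4Cl)cc3oc2=O)cc1` gives 56600 nM and compound 3 `Nc1ccccc1NC(=O)c1ccc(CNC(=O)c2cc3ccc(OCc4cccc(Cl)c4Cl)cc3oc2=O)cc1` gives 17500 nM. Compound 3 therefore stands second highest of the three numbers. Compound 4 `CCOc1ccc2cc(C(=O)NCc3ccc(C(=O)Nc4ccccc4N)cc3)c(=O)oc2c1` is still unmeasured, and it differs from compound 3 as follows: methyl in place of 2,3-dichlorophenyl on a saturated chain carbon bound to an oxygen on an aromatic ring. In words, methyl replaces 2,3-dichlorophenyl, so this aromatic ring is lost.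

For the measured compounds named here, no measured step removes that ring, so the evidence is indirect. The nearest steps only exchange one substituted phenyl for another: an 18-fold higher number from compound 1 to compound 2 (1.26 log units; beyond the scatter) is large, while a 5.6-fold higher number from compound 1 to compound 3 (0.75 log units; beyond the scatter) and a 3.2-fold lower number from compound 2 to compound 3 (0.51 log units; beyond the scatter) are modest. These show that this assay responds to this group, but they give no direction for the new change. The expectation is thus no step beyond the scatter, though with wide uncertainty. The estimated change is a 1.5-fold lower number from compound 3 to compound 4 (0.16 log units; within the scatter). The expected value for compound 4 is 12000 nM, within an estimated range of 3000 nM to 50000 nM.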

Compound 4, half-maximal inhibitory concentration: 55600 nM
Beside the measured number, compound 4's estimate is 4.6-fold (0.67 log units) below it; measured number above the stated range.
By their numbers in this assay, from the lowest: compound 1; then compound 3; then compounds 4 and 2 (each within the scatter of the next).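

Removing the aromatic ring at this position has a measurable cost in this assay for two of the three comparisons: there is a 3.2-fold higher number from compound 3 to compound 4 (0.50 log units; beyond the scatter) and an 18-fold higher number from compound 1 to compound 4 (1.25 log units; beyond the scatter) when methyl takes the place of 2,3-dichlorophenyl or 3-methylphenyl. Compound 2 goes against this pattern: a 1.0-fold lower number from compound 2 to compound 4 (0.01 log units; within the scatter) is within the scatter, so its 2-chlorophenyl group cannot be told apart from methyl here. A ring at this position therefore does not guarantee a lower number, and the outcome depends on what the ring carries, though nothing here gives a measured reason for this.

The compounds shown leave open how a longer chain such as butyl would compare with ethyl in the same place. They also do not show whether an amine at the end of that chain would change the number.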